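Compound 3 to Compound 4 in Mouse Liver Microsomes

This account rests on a few compounds, and the source may have more. Where it says the series, first, only, none or still open, it means among the compounds named here.

Measured compounds:
compound 1, `CNC(=O)c1ccc(-c2cnc3nnn(C(C)c4cc5cc(-c6cnn(C)c6)cnc5cc4F)c3n2)cc1F`: 24 uL/min
compound 2, `CC(c1c(F)cc2ncc(-c3cnn(C)c3)cc2c1F)n1nnc2ncc(-c3ccc(C(N)=O)c(F)c3)nc21`: 50 uL/min
compound 3, `CNC(=O)c1ccc(-c2cnc3nnn(C(C)c4c(F)cc5ncc(-c6cnn(C)c6)cc5c4F)c3n2)cc1F`: 187 uL/min

In an ADME assay on microsomes from liver (Mus musculus) for metabolic stability, read by LC-MS, using NADPH, with stated times of 5 min and 30 min, tested at 1 uM (on this read-out higher numbers stand for fast clearance and lower numbers for slow clearance), compound 3 gives 187 uL/min, the highest number of the three. The two steps that reach it are a 7.8-fold higher number from compound 1 to compound 3 (0.89 log units; beyond the scatter) and a 3.7-fold higher number from compound 2 to compound 3 (0.57 log units; beyond the scatter), both beyond the scatter. Compound 4, `CC(c1c(F)cc2ncc(-c3cnn(C)c3)cc2c1F)n1nnc2ncc(-c3ccncc3)nc21`, has not yet been measured. It differs from compound 3 in one place: pyridin-4-yl in place of 3-fluoro-4-(methylcarbamoyl)phenyl on an aromatic carbon. Going by the values given here, neither measured step touches this part of the molecule; the steps into compound 3 concern a fluoro on an aromatic carbon and a methyl on the amide-type nitrogen, so no step bears directly on the change to compound 4. With no guide from the measured pairs, compound 4 is expected to stay near compound 3, with an estimated step of a 1.6-fold lower number from compound 3 to compound 4 (0.19 log units; within the scatter) that may well fall within the scatter. The estimate for compound 4 in this assay is 120 uL/min, with a range from 40 uL/min to 350 uL/min.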

Compound 4, intrinsic clearance in a liver preparation (reported as CLH), per the amount of preparation that the assay uses: 106 uL/min
The estimate for compound 4 lay 1.1-fold (0.05 log units) above the measured number; the range from low to high includes it.
By their numbers in this assay, from the lowest: compound 1; then compound 2; then compounds 4 and 3 (each within the scatter of the next).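

In this assay, the step at this position, on the aromatic carbon next to the ring nitrogen, is a 1.8-fold lower number from compound 3 to compound 4 (0.25 log units; within the scatter), so exchanging 3-fluoro-4-(methylcarbamoyl)phenyl for pyridin-4-yl stays within the scatter even though the group shrinks from 11 heavy atoms to 6. Measured against the unmethylated amide, the same position gives a 2.1-fold higher number from compound 2 to compound 4 (0.33 log units; beyond the scatter), so of the two groups carrying an amide, only 4-carbamoyl-3-fluorophenyl separates from pyridin-4-yl, and only modestly. Nothing measured here accounts for either step.

The compounds shown leave open whether a piperazine or a carboxylic acid on the ring at this position would give a number lower than that of compound 2. They also leave open whether pyridin-4-yl would behave alike on the core of compound 1.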